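The source may report more compounds than this note shows. Statements on the series, on what has been measured and on what is new or still open speak of the compounds shown alone.

In an ADME assay on MT4 cells (Homo sapiens) for cytotoxicity, read by MTT assay, with a stated time of 5 days (on this read-out higher numbers stand for lower toxicity in this test and lower numbers for higher toxicity in this test), compound 1 `O=C(CSc1ncnn1-c1ccc(Cl)cc1Cl)Nc1ccccc1[N+](=O)[O-]` gives 187000 nM and compound 2 `CC(=O)c1ccc(NC(=O)CSc2ncnn2-c2ccc(Cl)cc2Cl)c(Br)c1` gives 114000 nM on the same read-out, two values that lie within the usual scatter of each other. Compound 2 therefore cannot be placed above or below compound 1 on these numbers. For the measured compounds named here, no step between measured compounds that differ in one place is available to guide the next comparison. Compound 3 `COC(=O)c1ccc(NC(=O)CSc2ncnn2-c2ccc(Cl)cc2Cl)c(Br)c1` departs from compound 2 at a single place: methoxy in place of methyl on a carbonyl carbon in words, methoxy in place of methyl on a carbonyl carbon, which reads as acetyl to methoxycarbonyl when cut one bond further out. For this change no shift beyond the scatter is expected in this assay and no direction is favoured, an expectation that rests only on compound 1 at 187000 nM and compound 2 at 114000 nM sitting so close together. The estimated step of a 1.0-fold higher number from compound 2 to compound 3 (0.00 log units; within the scatter) is small on this reading. Compound 3 is expected at 115000 nM with an estimated range from 55000 nM to 230000 nM as its likely span.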

Compound 3, half-maximal cytotoxic concentration: 59300 nM
For compound 3 the middle estimate is 1.9-fold (0.29 log units) above the measured one; measured number inside the range.
By their numbers in this assay, from the lowest: compounds 3, 2 and 1 (each within the scatter of the next, the first and the last beyond it).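

In this assay, putting methoxy in place of methyl on a carbonyl carbon gives a 1.9-fold lower number from compound 2 to compound 3 (0.28 log units; within the scatter), so acetyl and methoxycarbonyl cannot be told apart on this read-out. This is the first comparison among the compounds shown that isolates a single place, and it shows that here the added oxygen, with the one hydrogen-bond acceptor counted for methoxy, brings no shift that can be separated from the scatter of repeated measurements. No measurement shown here offers an explanation for this result.

On these data alone, it remains open whether another group on this carbonyl carbon, such as an amine to give an amide, a hydroxyl to give a carboxylic acid, or a longer chain in place of methoxy, would produce a step beyond the scatter. The compounds shown also offer a single-place comparison only at this carbonyl carbon, so they leave open how changes elsewhere on the shared core would read in this cytotoxicity test, and whether any such change would alter what is seen here.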